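The source may report more compounds than this note shows. Statements on the series, on what has been measured and on what is new or still open speak of the compounds shown alone.

In an ADME assay on L929 cells (Mus musculus, culture collection number NCTC 929) for cytotoxicity, read by MTT assay, with a stated time of 72 h (on this read-out lower numbers stand for stronger inhibition and higher numbers for weaker inhibition), compound 1 `Cc1cc(O)c(C(=O)NCCCc2ccccc2)c(=O)o1` gives 143000 nM and compound 2 `CCCCCCCCCC(=O)c1c(O)cc(C)oc1=O` gives 134000 nM while compound 3 `CCCCCCCCc1c(O)cc(C)oc1=O` gives 145000 nM on the same scale. Compound 3 therefore stands within the scatter of both others, and the three cannot be ranked. Compound 4 `CCCCCCc1c(O)cc(C)oc1=O` is reached from compound 3 by hydrogen in place of ethyl on a saturated chain carbon, six bonds along the chain from an aromatic carbon as a single change, hydrogen in place of ethyl on a saturated chain carbon, six bonds along the chain from an aromatic carbon. For the measured compounds named here, no measured pair shows this change alone, so the expectation rests on compound 3 at 145000 nM and its neighbours within the scatter. No step beyond the scatter is expected in this assay in either direction. The estimated move is a 1.1-fold higher number from compound 3 to compound 4 (0.03 log units; within the scatter) and stays inside the scatter. The estimated value for compound 4 is 155000 nM with 90000 nM to 280000 nM as its expected range.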

Compound 4, half-maximal inhibitory concentration: > 200000 nM
Compound 4 ended at the assay's limit (the forecaster's own chance of this, stated with the estimate: 10%); middle value at least 1.2-fold (0.11 log units) away from the limit.
By their numbers in this assay, from the lowest: compounds 2, 1 and 3 (each within the scatter of the next). At a limit, above all of these: compound 4.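

The pair of compounds differing only at this saturated chain carbon is the first shown to isolate a single change, and hydrogen in place of ethyl gives an at least 1.3-fold higher number from compound 3 to compound 4 (0.13 log units; that floor lies within the scatter). That floor lies within the scatter, so this change is not shown to exceed it. The value of compound 4 is a limit and not a number, and the true size of the step stays unread because of it: the limit of > 200000 nM in this assay, at which 1 of the 4 values shown sits.

The compounds shown leave open how a longer chain would read in this assay. They also leave open what an amine or a carboxylic acid on this saturated chain carbon would do.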